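Halogen swap on the ring nitrogen aryl group

A few compounds are considered here, and "the series" means these few. Any claim that something is new, unique, unknown or untested is made for them only; others in the source may bear on it.

Compound 1 `CN(C)/C=N/c1c(C=O)c(-c2ccc(Cl)cc2)nn1-c1cccc(Cl)c1`: 7400 nM
Compound 2 `CN(C)/C=N/c1c(C=O)c(-c2ccc(Cl)cc2)nn1-c1ccc(Br)cc1`: > 100000 nM (a limit of the assay, not a number)
Compound 3 `Cc1ccc(-c2cc(/N=C/N(C)C)n(-c3cccc(Cl)c3)n2)cc1`: > 100000 nM (a limit of the assay, not a number)

In a functional assay on NPC-TW01 cells (Homo sapiens) for inhibition, read by MTT assay, with a stated time of 72 h (a higher number here means a weaker inhibitor of growth, a lower number a stronger inhibitor of growth), compound 1 gives 7400 nM. Compound 2 reaches only > 100000 nM, a limit of the assay. The change between them, (4-bromophenyl in place of 3-chlorophenyl on an aromatic nitrogen), produced an at least 13-fold higher number from compound 1 to compound 2 (1.13 log units; beyond the scatter).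

Compound 3 gives > 100000 nM, again a limit. How the core of compound 3 differs from that of compound 1 is not broken down here. Compound 4 `Cc1ccc(-c2cc(/N=C/N(C)C)n(-c3ccc(Br)cc3)n2)cc1` carries the same kind of change, (4-bromophenyl in place of 3-chlorophenyl on an aromatic nitrogen); around the place, the ring atom two bonds away bears a 4-methylphenyl group rather than a 4-chlorophenyl group and a formyl group.

Because compound 3 already sits at the limit of > 100000 nM in this assay, at which 2 of the 3 values shown sit, compound 4 is expected to stay there. In this assay the expected step is a step that the limit leaves unreadable from compound 3 to compound 4. Compound 4 is estimated at 200000 nM.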

Compound 4, concentration for 50% growth inhibition: > 100000 nM
Compound 4 gave a limit, no number; the forecaster's own chance of this, stated with the estimate: 95%; the middle value lies beyond the limit too.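

For the compounds shown here, compound 3 and compound 4 both give only a limit of the assay, not a number, and no step between them can be read. The compounds shown leave open whether 4-bromophenyl in place of 3-chlorophenyl weakens growth inhibition on the core of compound 3, as it does on the core of compound 1.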